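Adding a Terminal Amine to a Lipidated Lysine Oligomer

The source may report more compounds than this note shows. Statements on the series, on what has been measured and on what is new or still open speak of the compounds shown alone.

This account concerns cytotoxicity measured in an ADME assay on MDCK cells (Canis lupus familiaris) for cytotoxicity, read by resazurin assay, with a stated time of 3.5 h; on this read-out lower numbers stand for stronger inhibition and higher numbers for weaker inhibition. Among the measured compounds shown here, compound 1, `CCCCCCCCCCCC(=O)NC(CCCCN)C(=O)NCCCCCCCCCCCC(=O)NC(CCCCN)C(=O)NCCCCCCCCCCCC(=O)NC(CCCCN)C(=O)O`, is the only compound of the three measured that yields an actual number: in this assay compound 1 gives 75000 nM. Compound 2, `NCCCCC(N)C(=O)NCCCCCCCCCCCC(=O)NC(CCCCN)C(=O)O`, returns only a limit of the assay in this assay, > 800000 nM, which is the limit of > 800000 nM in this assay, at which 1 of the 3 values shown sits. Compound 3, `NCCCCCCCCCCCC(=O)NC(CCCCN)C(=O)NCCCCCCCCCCCC(=O)NC(CCCCN)C(=O)O`, likewise returns a limit in this assay, > 150000 nM, which is the limit of > 150000 nM in this assay, at which 1 of the 3 values shown sits. For the measured compounds named here, with two of the three values standing at limits, no step between measured compounds can be sized, and compound 1 stands alone as the single number.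

Compound 4, `NCCCCCCCCCCCC(=O)NC(CCCCN)C(=O)NCCCCCCCCCCCC(=O)NC(CCCCN)C(=O)NCCCCCCCCCCCC(=O)NC(CCCCN)C(=O)O`, has not yet been tested. It differs from compound 1 by amino in place of hydrogen on a saturated chain carbon, ten or more bonds along the chain from a carbonyl carbon. Going by the values given here, no measured pair shows this change on its own. Compound 3 also bears an amino in place of hydrogen on a saturated chain carbon, and its result in this assay is the limit > 150000 nM. On that basis a step upward, toward weaker inhibition, is expected for the change a 2.0-fold higher number from compound 1 to compound 4 (0.30 log units; within the scatter), with a fair chance that only a limit is reported. Compound 4 is estimated at 150000 nM in this assay, within a range from 60000 nM to 400000 nM.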

Compound 4, half-maximal inhibitory concentration: 91000 nM
Compound 4: middle estimate off by 1.6-fold (0.22 log units), on the high side; low and high end bracket the measured number.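

In this assay, among the compounds shown here, amino in place of hydrogen on a saturated chain carbon, ten or more bonds along the chain from a carbonyl carbon, now has a size for the first time: a 1.2-fold higher number from compound 1 to compound 4 (0.08 log units; within the scatter). At this position on the full three-lysine oligomer, therefore, the read-out does not separate the free amine from the plain chain end, and compound 1 and compound 4 count as equal within repeat measurement. The earlier compounds could not show this, as compound 3, which also carries the terminal amino group, returned only a limit of the assay and gave no number to set against compound 1: the limit of > 150000 nM in this assay, at which 1 of the 4 values shown sits.

The compounds shown leave open whether a carboxylic acid or a guanidine at this chain end, or a longer chain in place of the present one, would produce a step beyond the scatter. For the compounds shown here, also open is how the amino change reads on a shorter oligomer, where no pair of compounds differing in this one place and carrying actual numbers is available.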